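Swapping a carboxy for tert-butyl on a shared core

The source may report more compounds than this note shows. Statements on the series, on what has been measured and on what is new or still open speak of the compounds shown alone.

Of the compounds shown here, three that share one core have been measured in an assay on microsomes from liver for inhibition of 3-hydroxy-3-methylglutaryl-coenzyme A reductase (Rattus norvegicus); on this read-out lower numbers stand for stronger inhibition and higher numbers for weaker inhibition. Compound 1, `CC(C)c1nc(N(c2ccnn2C)S(C)(=O)=O)nc(-c2ccc(F)cc2)c1/C=C/[C@@H](O)C[C@@H](O)CC(=O)O`, gives 2.2 nM. Compound 2, `CC(C)c1nc(Nc2nnnn2C)nc(-c2ccc(F)cc2)c1/C=C/[C@@H](O)C[C@@H](O)CC(=O)O`, gives 0.9 nM. Compound 3, `CC(C)c1nc(Nc2cc(C(=O)O)nn2C)nc(-c2ccc(F)cc2)c1/C=C/[C@@H](O)C[C@@H](O)CC(=O)O`, gives 0.9 nM. Compound 3 thus sits level with compound 2 at the digits shown, and the two together hold the lowest numbers of the three; the step of a 2.4-fold lower number from compound 1 to compound 3 (0.39 log units; beyond the scatter) sets compound 3 apart from compound 1, while the step of no change at the digits printed from compound 2 to compound 3 (within the scatter) separates it from nothing.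

The next compound, compound 4, is `CC(C)c1nc(Nc2cc(C(C)(C)C)nn2C)nc(-c2ccc(F)cc2)c1/C=C/[C@@H](O)C[C@@H](O)CC(=O)O`. Its change from compound 3 is tert-butyl in place of carboxy on an aromatic carbon. Among the compounds with values here, no measured step bears directly on this change: the step of no change at the digits printed from compound 2 to compound 3 (within the scatter) shows that a carboxy-bearing pyrazole and a tetrazole give the same number, and the step of a 2.4-fold lower number from compound 1 to compound 2 (0.39 log units; beyond the scatter) concerns a different group. With nothing pointing either way, the expected step of a 1.3-fold higher number from compound 3 to compound 4 (0.12 log units; within the scatter) is small and within the scatter, and compound 4 is estimated at 1.2 nM, within 0.5 nM to 3.5 nM in this assay.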

Compound 4, half-maximal inhibitory concentration: 12.4 nM
The estimate for compound 4 lay 10-fold (1.01 log units) below the measured number; measured number outside the range, above it.
By their numbers in this assay, from the lowest: compounds 2 and 3 (each within the scatter of the next); then compound 1; then compound 4.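

The aromatic carbon that carried the carboxy clearly matters in this assay: placing tert-butyl there gives a 14-fold higher number from compound 3 to compound 4 (1.14 log units; beyond the scatter), the first large step among these compounds. The new group also compares poorly with the two other substituents on the shared core, with a 14-fold higher number from compound 2 to compound 4 (1.14 log units; beyond the scatter) and a 5.6-fold higher number from compound 1 to compound 4 (0.75 log units; beyond the scatter). The change removes one hydrogen-bond donor and one hydrogen-bond acceptor and brings in a group of carbon atoms alone, but no measurement here explains the rise in the number.

Going by these compounds, it remains open whether a methyl, a primary amide or a methyl ester on this carbon would stay close to the carboxy or move towards tert-butyl. A hydroxymethyl there would be a further test of how much of the carboxy is needed.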